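Replacing the furan carbonyl of an inactive compound

The source may report more compounds than this note shows. Statements on the series, on what has been measured and on what is new or still open speak of the compounds shown alone.

Compound 1 `C=C(C)CCC[C@]1(C)C2=CCC[C@](C)(CC(=O)c3ccoc3)[C@H]2CC[C@H]1C`: > 100000 nM
Compound 2 `C=C(C)CC[C@]1(C)C2=CCC[C@](C)(C[C@H](O)c3ccoc3)[C@H]2CC[C@H]1C`: 30000 nM
Compound 3 `C=C(C)CC[C@]1(C)C2=CCC[C@](C)(C[C@@H](O)C3=CC(=O)OC3O)[C@H]2CC[C@H]1C`: 3600 nM

In a functional assay on HT-29 cells (Homo sapiens) for antiproliferative activity, read by XTT assay, with a stated time of 72 h (on this read-out higher numbers stand for weaker inhibition and lower numbers for stronger inhibition), compound 1 is known only by a limit (> 100000 nM), not by a number. Among the measured compounds shown here, it stands at the limit of > 100000 nM in this assay, at which 1 of the 3 values shown sits, and is the only compound there.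

The compound still to be measured is compound 4 `C=C(C)CCC[C@]1(C)C2=CCC[C@](C)(C[C@H](O)C3=CC(=O)OC3O)[C@H]2CC[C@H]1C`. It keeps the core of compound 1 but changes one group (a group of 9 heavy atoms (5 carbon, 4 oxygen; one five-membered non-aromatic ring with 1 hetero atom) in place of a group of 7 heavy atoms (5 carbon, 2 oxygen; one five-membered aromatic ring with 1 hetero atom), on a saturated chain carbon bound to a saturated ring carbon). The (furan-3-yl)carbonyl leaves, and a group with a five-membered non-aromatic ring enters.

For the measured compounds named here, one measured step bears on this change (an 8.3-fold lower number from compound 2 to compound 3 (0.92 log units; beyond the scatter)). That step brings in the same kind of group, and it is modest but beyond the scatter. Compound 3, which carries that group, gives 3600 nM in this assay. Compounds 2 and 3 also differ from compound 4 elsewhere, so the step transfers only loosely.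

A move to a lower number is therefore expected, and the estimated step is an at least 22-fold lower number from compound 1 to compound 4 (1.34 log units; beyond the scatter). For compound 4 the expected value is 4500 nM (estimated range 1300 nM to 16000 nM).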

Compound 4, half-maximal inhibitory concentration: 3000 nM
Estimate against measurement, compound 4: 1.5-fold (0.18 log units) above; the measured number falls inside the stated range.
By their numbers in this assay, from the lowest: compounds 4 and 3 (each within the scatter of the next); then compound 2. At a limit, above all of these: compound 1.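

On the core of compound 1, the group with a five-membered non-aromatic ring gives a measurable value in this assay, where the (furan-3-yl)carbonyl gave none, with an at least 33-fold lower number from compound 1 to compound 4 (1.52 log units; beyond the scatter). That step is large, whereas an 8.3-fold lower number from compound 2 to compound 3 (0.92 log units; beyond the scatter) was modest, so the earlier compounds had not shown a change of this size at this place, and the new step is a bound rather than an exact size. Compound 1 is known only by a limit: the limit of > 100000 nM in this assay, at which 1 of the 4 values shown sits.

The change removes the furan ring and the carbonyl together, so the compounds shown do not tell how much of the step belongs to each. They also leave open whether an amine or a carboxylic acid on the same saturated chain carbon would give a similar value.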